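Pyridyl Ring in Place of a Methylphenyl Group

The source may report more compounds than this note shows. Statements on the series, on what has been measured and on what is new or still open speak of the compounds shown alone.

Compound 3 `C/C(=N\Cc1cccc(C)c1)c1c(O)c2ccccc2oc1=O` stands lowest of the two numbers in an assay on isolated protein for inhibition of myosin-2 (Bos taurus), read by spectrophotometry, with a stated time of 24 min (on this read-out lower numbers stand for stronger inhibition and higher numbers for weaker inhibition), where compound 3 gives 4900 nM. Compound 1 `C/C(=N\CC(C)C)c1c(O)c2ccccc2oc1=O` gives 34000 nM in this assay. Compound 2 `C/C(=N\Cc1ccccc1)c1c(O)c2ccccc2[nH]c1=O` carries a different core and reaches only a limit in this assay, at >= 100000 nM (the limit of >= 100000 nM in this assay, at which 1 of the 3 values shown sits). Compound 4 `C/C(=N\Cc1ccccn1)c1c(O)c2ccccc2oc1=O` differs from compound 3 in one place: pyridin-2-yl in place of 3-methylphenyl on a saturated chain carbon bound to a double-bonded nitrogen. Among the compounds with values here, the single measured step at this position is a 6.9-fold lower number from compound 1 to compound 3 (0.84 log units; beyond the scatter), which concerns an aromatic ring against a small branched chain, not one aromatic ring against another. The expected step, a 2.4-fold higher number from compound 3 to compound 4 (0.39 log units; beyond the scatter) in this assay, is therefore a modest rise. Compound 4 is estimated to give 12000 nM in this assay, within a range of 4000 nM to 40000 nM.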

Compound 4, half-maximal inhibitory concentration: 22000 nM
The estimate for compound 4 lay 1.8-fold (0.26 log units) below the measured number, and the stated range covers the measured number.
By their numbers in this assay, from the lowest: compound 3; then compounds 4 and 1 (each within the scatter of the next). At a limit, above all of these: compound 2.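

In this assay, exchanging one aromatic ring for another on this carbon gives a 4.5-fold higher number from compound 3 to compound 4 (0.65 log units; beyond the scatter) and so shows that an aromatic ring alone does not secure the lower number of compound 3. The pair of pyridin-2-yl and isopropyl gives a 1.5-fold lower number from compound 1 to compound 4 (0.19 log units; within the scatter) and so does not separate these two groups, although one is aromatic and the other is a small branched chain. No measurement shown accounts for these steps. Open, on these data alone, is how a plain phenyl ring, or a ring carrying an amine or a carboxylic acid, would read on this carbon with the core of compound 3.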